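Swapping the bromophenyl arm for a thiophene

The compounds below may be only part of what the source reports. "The series", "measured", "known", "first", "only" and "open" are said of these compounds alone.

Of the compounds shown here, three sharing one core have been measured in a functional assay on UO-31 cells (Homo sapiens) for inhibition, read by sulforhodamine B assay, with a stated time of 48 h, tested at 10 uM; a higher number here means more inhibition at the concentration tested (going by the name of the read-out), a lower number less inhibition. Compound 1 `c1ccc(-c2cn3ccnc3c(-c3ccc4ncn(C5CCCCC5)c4c3)n2)cc1` gives 55.2%, compound 2 `Clc1ccc(-c2cn3ccnc3c(-c3ccc4ncn(C5CCCCC5)c4c3)n2)cc1` gives 36.1%, and compound 3 `Brc1ccc(-c2cn3ccnc3c(-c3ccc4ncn(C5CCCCC5)c4c3)n2)cc1` gives 42.9%. Compound 3 holds the second highest of the three numbers: it sits a number 6.8 percentage points higher from compound 2 to compound 3 (within the scatter), while the gap a number 12.3 percentage points lower from compound 1 to compound 3 (beyond the scatter) is beyond the scatter, as is the drop a number 19.1 percentage points lower from compound 1 to compound 2 (beyond the scatter).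

Compound 4 `c1csc(-c2cn3ccnc3c(-c3ccc4ncn(C5CCCCC5)c4c3)n2)c1` is the next compound, not yet measured. Compared with compound 3 it carries thiophen-2-yl in place of 4-bromophenyl on an aromatic carbon. For the measured compounds named here, no measured step swaps one ring for another, so only indirect guidance exists. Going by the values given here, the step of a number 12.3 percentage points lower from compound 1 to compound 3 (beyond the scatter) shows that adding bromo lowered the number modestly; compound 4 loses that bromine but also changes the ring itself, which no measured pair covers. The direction of the ring change is therefore open, and the expected step is a number 5.1 percentage points higher from compound 3 to compound 4 (within the scatter), likely within the scatter. Compound 4 is thus estimated at 48%, with a range from 28% to 66%.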

Compound 4, a percentage reported as inhibition, at one concentration (the size of the read-out at that concentration, not a potency): 10.9%
Estimate against measurement, compound 4: 37.1 percentage points above, outside the stated range (below it).
By their numbers in this assay, from the lowest: compound 4; then compounds 2 and 3 (each within the scatter of the next); then compound 1.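

The ring itself counts at this position, next to the ring nitrogen: in this assay, thiophen-2-yl in place of 4-bromophenyl gives a number 32 percentage points lower from compound 3 to compound 4 (beyond the scatter). The loss holds against the other two arms, with a number 25.2 percentage points lower from compound 2 to compound 4 (beyond the scatter) and a number 44.3 percentage points lower from compound 1 to compound 4 (beyond the scatter), so compound 4 stands lowest of the four, with each of its steps beyond the scatter. The earlier compounds shown here showed only that a halogen on the phenyl ring lowered the number, whereas these steps show that removing the bromine along with the six-membered ring does not recover the number of compound 1.

Nothing at hand explains why the thiophene arm behaves this way. On these data alone, whether the drop follows from the sulfur, the five-membered ring or the smaller arm stays open, and a furan-2-yl or pyridin-3-yl group at this place would help to separate these.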